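The compounds below may be only part of what the source reports. "The series", "measured", "known", "first", "only" and "open" are said of these compounds alone.

Of the compounds shown here, three built on one shared core have been measured in a functional assay on M14 cells (Homo sapiens) for antiproliferative activity, with a stated time of 72 h; a lower number here means a stronger inhibitor, a higher number a weaker inhibitor. Compound 1 `C=CC[C@H]1C[C@]2([C@@H](C)Cc3ccc(OC)cc3)OCOC2=CC1=O` gives 20 nM. Compound 2 `C=CC[C@H]1C[C@]2([C@@H](C)Cc3cc(OC)c(OC)cc3F)OCOC2=CC1=O`, which carries a fluoro group and two methoxy groups on its aromatic ring, gives 14 nM. Compound 3 `C=CC[C@H]1C[C@]2([C@@H](C)Cc3cc(NC(C)=O)c(OC)cc3F)OCOC2=CC1=O` has an acetamido group where compound 2 has one of its methoxy groups; in this assay compound 3 gives 52 nM. That is the highest number of the three: its nearest neighbour is compound 1 and its furthest is compound 2. Among the measured compounds shown here, the single one-place step among the measured compounds, acetamido in place of methoxy on an aromatic carbon, is a 3.7-fold higher number from compound 2 to compound 3 (0.57 log units; beyond the scatter), so the acetamido compound is the weaker inhibitor.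

Compound 4 `C=CC[C@H]1C[C@]2([C@@H](C)Cc3ccc(OC)cc3F)OCOC2=CC1=O` differs from compound 3 by hydrogen in place of acetamido on an aromatic carbon, in words hydrogen in place of acetamido on an aromatic carbon. For the measured compounds named here, no measured step removes an acetamido group outright. Still, because the step of a 3.7-fold higher number from compound 2 to compound 3 (0.57 log units; beyond the scatter) shows that bringing the acetamido in raised the number, and because compound 1 with 20 nM and compound 2 with 14 nM both lack it and sit lower, taking the acetamido away is expected to bring the number back down. The expected change is a 2.9-fold lower number from compound 3 to compound 4 (0.46 log units; beyond the scatter). Compound 4 is therefore estimated at 18 nM, with a range from 8 nM to 45 nM.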

Compound 4, half-maximal inhibitory concentration: 14 nM
The estimate for compound 4 lay 1.3-fold (0.11 log units) above the measured number; measured number inside the range.
By their numbers in this assay, from the lowest: compounds 2, 4 and 1 (each within the scatter of the next); then compound 3.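

Of the three groups now seen on this aromatic carbon, which sits ortho to a methoxy group and para to a fluoro group, only acetamido stands apart in this assay: putting hydrogen in its place gives a 3.7-fold lower number from compound 3 to compound 4 (0.57 log units; beyond the scatter), the same size as the step that brought the acetamido in against methoxy. Hydrogen and methoxy on this carbon cannot be told apart, with no change at the digits printed from compound 2 to compound 4 (within the scatter), so the methoxy group here is not needed to keep the number low, and the acetamido result reflects something about that group rather than the loss of methoxy. The fluoro group adds a further finding on a different carbon, since fluoro in place of hydrogen gives a 1.4-fold lower number from compound 1 to compound 4 (0.15 log units; within the scatter), which means this assay does not separate the compound with it from the one without it.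

From the compounds shown here alone, it remains open whether a plain amine, a hydroxyl group or a longer chain on the same carbon would group with hydrogen and methoxy or with acetamido. Nothing given here explains why the acetamido compound has the higher number.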